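The source may hold more compounds than are shown below. What is called first, only, known or untested is meant among the compounds shown, and "the series" means these compounds.

Working notes on the series. Compound 1 `CCN(C/C=C/C#CC(C)(C)C)Cc1cccc(OC[Si](C)(C)c2ccc(F)cc2)c1` gives 60 nM in a functional assay on liver (Sus scrofa) for inhibition of squalene monooxygenase (Homo sapiens), using microsomes; a higher number here means a weaker inhibitor, a lower number a stronger inhibitor. Within the data shown here, compound 2 `CCN(C/C=C/C#CC(C)(C)C)Cc1cccc(OC[Si](C)(C)c2ccc(C(=O)C(F)(F)F)cc2)c1` gives 5000 nM in this assay, the highest of the two numbers so far; its nearest neighbour is compound 1, and the step of an 83-fold higher number from compound 1 to compound 2 (1.92 log units; beyond the scatter) lies well beyond the scatter. Compound 3 `C=Cc1ccc([Si](C)(C)COc2cccc(CN(CC)C/C=C/C#CC(C)(C)C)c2)cc1` is not yet measured. It differs from compound 2 by vinyl in place of (trifluoromethyl)carbonyl on an aromatic carbon. Among the measured compounds shown here, the only measured step that touches this position is an 83-fold higher number from compound 1 to compound 2 (1.92 log units; beyond the scatter), a large rise on installing the (trifluoromethyl)carbonyl in place of fluoro. Compound 3 removes that same (trifluoromethyl)carbonyl again and carries vinyl there instead, so the change undoes the substitution that produced the rise, though vinyl is not fluoro and the two compounds need not land at the same number. A large drop in this assay is therefore expected, most of the way back toward the number of compound 1, with the estimated step of a 33-fold lower number from compound 2 to compound 3 (1.52 log units; beyond the scatter). Compound 3 is expected to give about 150 nM, in a range from 40 nM to 600 nM.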

Compound 3, half-maximal inhibitory concentration: 70 nM
Estimate against measurement, compound 3: 2.1-fold (0.33 log units) above, within the range that was stated.
By their numbers in this assay, from the lowest: compounds 1 and 3 (each within the scatter of the next); then compound 2.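

In this assay the step of a 71-fold lower number from compound 2 to compound 3 (1.85 log units; beyond the scatter) shows that the large loss attached to the (trifluoromethyl)carbonyl is not a general cost of replacing fluoro at this aromatic carbon, since a group of 2 carbon atoms with no hydrogen-bond acceptor restores the number in full. The step of a 1.2-fold higher number from compound 1 to compound 3 (0.07 log units; within the scatter) places vinyl level with fluoro, so two quite different groups are accepted at this place on the ring, and of the three compounds only compound 2 goes against that reading. No evidence is at hand on what separates the (trifluoromethyl)carbonyl from the other two groups.

On these data alone, whether the loss follows the carbonyl or the trifluoromethyl part of that group stays open, and so does whether an acetyl, a nitrile, a carboxylic acid, an amine or a longer chain at this position would read like fluoro and vinyl or like the (trifluoromethyl)carbonyl. The compounds shown also share one core and one assay, so it remains open whether this reading of the position holds on any other core.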